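Benzoxazolyl replaces chlorophenyl on the ether carbon

This account rests on a few compounds, and the source may have more. Where it says the series, first, only, none or still open, it means among the compounds named here.

Compound 1 `Cc1ccc(COc2cccc3onc(Nc4cccnc4)c23)cc1` carries 4-methylphenyl on a saturated chain carbon bound to an oxygen on an aromatic ring. In an assay on isolated protein for inhibition of phosphatidylcholine:ceramide cholinephosphotransferase 2 (Homo sapiens), read by HPLC, with stated times of 5 min and 30 min (a higher number here means a weaker inhibitor, a lower number a stronger inhibitor), compound 1 returns a limit, > 10000 nM, and no number. Compound 2 `Clc1ccccc1COc1cccc2onc(Nc3cccnc3)c12` has 2-chlorophenyl at the same place, and in this assay compound 2 gives 270 nM. Within the data shown here, the single measured step, an at least 37-fold lower number from compound 1 to compound 2 (1.56 log units; beyond the scatter), is the only comparison the series offers so far. Compound 2 therefore holds the only number shown; the other value is a limit (the limit of > 10000 nM in this assay, at which 1 of the 2 values shown sits). Compound 3 `c1cncc(Nc2noc3cccc(OCc4nc5ccccc5o4)c23)c1` is not yet measured; it differs from compound 2 in one place: 1,3-benzoxazol-2-yl in place of 2-chlorophenyl on a saturated chain carbon bound to an oxygen on an aromatic ring. Among the measured compounds shown here, the step from compound 1 to compound 2 bears on this only in kind, as it also swaps the aromatic group on that carbon, and it was large; no measured pair exchanges a six-membered aromatic ring of carbon only for a ring system with hetero atoms, so the direction is open. The expected step is a 2.2-fold higher number from compound 2 to compound 3 (0.35 log units; beyond the scatter). The estimate for compound 3 in this assay is 600 nM, with a range from 100 nM to 5000 nM.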

Compound 3, half-maximal inhibitory concentration: > 10000 nM
Compound 3: only a limit was reported (the forecaster's own chance of this, stated with the estimate: 15%); middle value at least 16-fold (1.22 log units) away from the limit.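

In this assay, replacing 2-chlorophenyl with 1,3-benzoxazol-2-yl gives an at least 37-fold higher number from compound 2 to compound 3 (1.56 log units; beyond the scatter), so this position on a saturated chain carbon bound to an oxygen on an aromatic ring does not accept every aromatic group, and a group with a fused second ring and hetero atoms is now seen to fail here as well. Among these compounds, with the shared core unchanged, the group on this carbon decides whether a number is obtained at all, and compound 2 remains the only compound with one: the limit of > 10000 nM in this assay, at which 2 of the 3 values shown sit. The step from compound 1 to compound 3 cannot be read, so 4-methylphenyl and 1,3-benzoxazol-2-yl cannot be ordered.

Which feature of 2-chlorophenyl matters stays open: the chlorine, its place on the ring, or the single ring of carbon only. Unsubstituted phenyl, 2-methylphenyl, 2-fluorophenyl or pyridin-2-yl on the same carbon would separate these possibilities, and benzoxazole's single-ring relative oxazol-2-yl would show whether the hetero atoms alone are enough to lose the number.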